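Second chloro on the core of compound 1

The source may hold more compounds than are shown below. What is called first, only, known or untested is meant among the compounds shown, and "the series" means these compounds.

Of the compounds shown here, three have been tested so far in a functional assay on IGROV-1 cells (Homo sapiens) for cytotoxicity, read by sulforhodamine B assay, with a stated time of 48 h; a lower number here means a stronger inhibitor of growth, a higher number a weaker inhibitor of growth. Compound 1 `ClCc1ccc(Cn2cnc3c(Cl)ncnc32)cc1` gives 25100 nM, the highest number of the three; compound 3 `ClCc1ccccc1Cn1cnc2ncnc(Cl)c21` gives 22900 nM, within the scatter of compound 1, while compound 2 `ClCc1cccc(Cn2cnc3c(Cl)nc(Cl)nc32)c1` gives 5120 nM, a clearly lower number. Compound 2 is the only one carrying a second chloro on the core. Compound 4 `ClCc1ccc(Cn2cnc3c(Cl)nc(Cl)nc32)cc1` has not yet been measured. It differs from compound 1 by chloro in place of hydrogen on an aromatic carbon, the change that sets compound 2 apart from the others. On that basis a step from compound 1 to compound 4 of a 3.6-fold lower number from compound 1 to compound 4 (0.55 log units; beyond the scatter) toward a lower number is expected. Compound 4 is estimated at 7000 nM, with a range from 2500 nM to 20000 nM.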

Compound 4, concentration for total growth inhibition: 30200 nM
The estimate for compound 4 lay 4.3-fold (0.63 log units) below the measured number, outside the stated range (above it).
By their numbers in this assay, from the lowest: compound 2; then compounds 3, 1 and 4 (each within the scatter of the next).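

At this position, between two ring nitrogen atoms, chloro in place of hydrogen gives a 1.2-fold higher number from compound 1 to compound 4 (0.08 log units; within the scatter) in this assay. Compound 2, which carries the same second chloro, gives 5120 nM, whereas compound 4 gives 30200 nM, so the second chloro alone does not bring the lower number of compound 2. Nothing available explains why this change leaves the number within the scatter.

Open, from the compounds shown here alone, is whether an amine or a methoxy group at this position would shift the number. Also open, going by these compounds, is whether the place of the chloromethyl group, rather than the second chloro, sets compound 2 apart.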